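This account rests on a few compounds, and the source may have more. Where it says the series, first, only, none or still open, it means among the compounds named here.

Three compounds from this study share the same cell-based read-out, a functional assay on BXPC-3 cells (Homo sapiens) for inhibition, read by MTT assay, with a stated time of 48 h (on this read-out higher numbers stand for weaker inhibition and lower numbers for stronger inhibition), and none of them gives a number. Compound 1, `COc1ccc2c(c1)c(C1CC(c3ccncc3)=NO1)cn2Cc1ccc(Cl)cc1`, reaches only a limit in this assay, > 100000 nM. Compound 2, `COc1ccc2c(C3CC(c4ccncc4)=NO3)cn(Cc3ccc(Cl)cc3)c2c1`, likewise reaches only a limit, > 100000 nM. Compound 3, `COc1ccc(C2=NOC(c3c[nH]c4ccccc34)C2)cc1OC`, also returns a limit rather than a value, > 100000 nM. So compound 3 stands nowhere in particular among the numbers shown: all three values sit at the same place, (the limit of > 100000 nM in this assay, at which 3 of the 3 values shown sit), and no step between measured compounds can be worked out.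

Compound 4, `COc1cc(C2=NOC(c3c[nH]c4ccccc34)C2)cc(OC)c1OC`, is the next compound, and it has yet to be measured. It differs from compound 3 by methoxy in place of hydrogen on an aromatic carbon. Going by the values given here, with every measured value sitting at the limit, there is no measured step from which to expect a direction, and the author expects the step from compound 3 to compound 4 to be a number no higher from compound 3 to compound 4 (the limit leaves the size open), that is, none beyond the scatter. Compound 4 is therefore estimated at 100000 nM, within a range from 30000 nM to 300000 nM, with a good chance that the assay again reports only a limit.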

Compound 4, half-maximal inhibitory concentration: 13500 nM
Estimate against measurement, compound 4: 7.4-fold (0.87 log units) above; the measured number lies below the stated range.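

In this assay, methoxy in place of hydrogen on an aromatic carbon, ortho to a methoxy group and meta to a large group, brings out a measurable number: compound 4 gives 13500 nM. The change amounts to an at least 7.4-fold lower number from compound 3 to compound 4 (0.86 log units; beyond the scatter), so a single added methoxy at this position is enough to shift the read-out beyond the scatter, and the size of the step has only a lower bound. Compound 4 is the only compound shown that gives a number rather than a limit: the limit of > 100000 nM in this assay, at which 3 of the 4 values shown sit.

The compounds shown leave open whether a hydroxyl, a fluorine, an amine or a longer chain such as ethoxy at this position would lower the number as methoxy does. They also leave open whether the same change would have any such effect on another core, such as that of compound 1.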